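Moving the Acid Out onto a Chain

A few compounds are considered here, and "the series" means these few. Any claim that something is new, unique, unknown or untested is made for them only; others in the source may bear on it.

Measured so far:
compound 1 `Cc1cc(C(=O)O)ccc1-c1noc(-c2ccc(C3CCCCC3)cc2)n1`: > 10000 nM
compound 2 `Cc1cc(-c2nc(-c3ccc(CCC(=O)O)cc3C)no2)ccc1OC(C)C`: 210 nM
compound 3 `COc1cc(-c2nc(-c3ccc(CCC(=O)O)cc3C)no2)ccc1OC(C)C`: 270 nM

Of the compounds shown here, three built on a shared core have been tested in a functional assay on CHO cells for agonist activity at sphingosine 1-phosphate receptor 5 (Homo sapiens), read by GTPgammaS binding; on this read-out higher numbers stand for an effect only at larger amounts of compound and lower numbers for an effect already at smaller amounts. Compound 1 returns > 10000 nM in this assay, and this is a limit of the assay, not a number. Compound 1 therefore stands at the limit of > 10000 nM in this assay, at which 1 of the 3 values shown sits, and no exact value is known for it. Compound 2 gives 210 nM in this assay. Compound 3 gives 270 nM in this assay. Among the compounds with values here, the only measured step, a 1.3-fold higher number from compound 2 to compound 3 (0.11 log units; within the scatter), concerns a group on a different ring and lies within the scatter, so it says nothing about the change now in question.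

Compound 4 `Cc1cc(CCCCCC(=O)O)ccc1-c1noc(-c2ccc(C3CCCCC3)cc2)n1` differs from compound 1 in one place: 5-carboxypentyl in place of carboxy on an aromatic carbon. Within the data shown here, no measured step covers this change directly. What the values show is that compound 1, whose carboxy sits directly on the ring, stays at the limit, while compounds 2 and 3, whose acid sits at the end of a short chain, return measurable numbers. On that basis a step in the direction of smaller numbers, an at least 25-fold lower number from compound 1 to compound 4 (1.39 log units; beyond the scatter), is expected from the limit to a measurable value. Compound 4 is estimated at 400 nM, with a range from 60 nM to 4000 nM.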

Compound 4, half-maximal effective concentration: 1080 nM
The estimate for compound 4 lay 2.7-fold (0.43 log units) below the measured number; the range from low to high includes it.
By their numbers in this assay, from the lowest: compounds 2 and 3 (each within the scatter of the next); then compound 4. At a limit, above all of these: compound 1.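

In this assay, putting 5-carboxypentyl in place of carboxy at this position, para to a large group, gives an at least 9.2-fold lower number from compound 1 to compound 4 (0.96 log units; beyond the scatter). On the core of compound 1, then, an acid at the end of a chain gives a measurable number, while an acid sitting directly on the ring stays at the limit, and the change adds only carbon atoms, since the two groups hold the same count of oxygen atoms, donors and acceptors. The true size of this step remains unknown because one end of it is a limit and not a number: the limit of > 10000 nM in this assay, at which 1 of the 4 values shown sits.

As far as these compounds go, what stays open is how the number depends on chain length at this position, whether for a shorter chain such as 2-carboxyethyl, a longer chain, or a chain ending in an amine instead of a carboxylic acid. Compounds 2 and 3 differ from compound 4 in more than one place, so their printed values leave open whether the remaining distance to compound 4 belongs to the chain or to the other parts of the molecule.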